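The compounds below may be only part of what the source reports. "The series", "measured", "known", "first", "only" and "open" are said of these compounds alone.

Measured so far in a functional assay on HT-29 cells (Homo sapiens) for antiproliferative activity, read by MTT assay, with a stated time of 24 h; a lower number here means a stronger inhibitor, a higher number a weaker inhibitor:
Compound 1 `COc1ccc(/C=C/C(=O)c2ccc(OC)c3c2OC(C)(C)C=C3)c(F)c1`: > 10000 nM, a limit.
Compound 2 `COc1ccc(C(=O)/C=C/c2ccc(O)cc2)c2c1C=CC(C)(C)O2`: > 10000 nM, a limit.

Compound 2 has no number on this read-out. Its value of > 10000 nM is only a limit. Among the measured compounds shown here, the series so far amounts to the limit of > 10000 nM in this assay, at which 2 of the 2 values shown sit.

Compound 3 `COc1ccc(C(=O)/C=C/c2cc(Cl)ccc2O)c2c1C=CC(C)(C)O2` carries 5-chloro-2-hydroxyphenyl in place of 4-hydroxyphenyl on a double-bonded chain carbon bound to a double-bonded chain carbon.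

For the measured compounds named here, the only measured step that bears on this change is a step that the two limits leave unreadable from compound 1 to compound 2. It falls on the same kind of chain carbon, but it offers no size to carry over. With that step unreadable, no step beyond the scatter is expected in this assay, and no direction can be assigned. The expected step is a step that the limit leaves unreadable from compound 2 to compound 3. A report of only a limit is also expected to be more likely than a number. For compound 3 the estimate is 12000 nM, with an expected range from 4000 nM to 30000 nM.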

Compound 3, half-maximal inhibitory concentration: 4970 nM
The estimate for compound 3 lay 2.4-fold (0.38 log units) above the measured number; measured number inside the range.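

In this assay, among the compounds shown here, compound 3 is the first member of the series to give a number rather than a limit, which marks the group on a double-bonded chain carbon bound to a double-bonded chain carbon as a place where a change can bring the read-out into the measurable range. Setting 5-chloro-2-hydroxyphenyl there gives an at least 2.0-fold lower number from compound 2 to compound 3 (0.30 log units; that floor lies within the scatter) and also an at least 2.0-fold lower number from compound 1 to compound 3 (0.30 log units; that floor lies within the scatter); both are floors set by a limit, so the true size of either step cannot be read. The rest of the series stays at a limit, so the number for compound 3 has no second number to stand against: the limit of > 10000 nM in this assay, at which 2 of the 3 values shown sit.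

The change brings in the chlorine and alters the hydroxyl's place on the ring in a single step, so the compounds shown do not tell which of the two carries the difference, and plain 2-hydroxyphenyl would separate them. Also open, on these data alone, is whether bromine in place of the chlorine, or an amine in place of the hydroxyl, would hold a measurable number at this place.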